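The source may report more compounds than this note shows. Statements on the series, on what has been measured and on what is new or still open speak of the compounds shown alone.

Working notes on the series. Compound 1 `COc1cc(-c2nn(-c3cccc(NC(=O)Nc4cc(C(F)(F)F)cc(C(F)(F)F)c4)c3)cc2-c2ccncc2)ccc1Cl` gives 855 nM in a functional assay on HOP-62 cells (Homo sapiens) for inhibition, read by sulforhodamine B assay, with a stated time of 48 h; a lower number here means a stronger inhibitor of growth, a higher number a weaker inhibitor of growth. Compound 2 `O=C(Nc1cccc(-n2cc(-c3ccncc3)c(-c3ccc(Cl)c(O)c3)n2)c1)Nc1cc(C(F)(F)F)cc(C(F)(F)F)c1` carries the change hydrogen in place of methyl on an oxygen on an aromatic ring relative to compound 1, and in this assay compound 2 gives 964 nM; the step is a 1.1-fold higher number from compound 1 to compound 2 (0.05 log units; within the scatter). Compound 3 `COc1cc(-c2nn(-c3cccc(NC(=O)Nc4ccc(Cl)c(C(F)(F)F)c4)c3)cc2-c2ccncc2)ccc1Cl` is built on a different core; how the core of compound 3 differs from the core of compound 1 is not broken down here. In this assay compound 3 gives 1310 nM, and its gaps to compound 1 and compound 2 are within the scatter. Compound 4 `O=C(Nc1cccc(-n2cc(-c3ccncc3)c(-c3ccc(Cl)c(O)c3)n2)c1)Nc1ccc(Cl)c(C(F)(F)F)c1` is not yet measured; it differs from compound 3 by hydrogen in place of methyl on an oxygen on an aromatic ring, the same change as that from compound 1 to compound 2, at the same place. The step of a 1.1-fold higher number from compound 3 to compound 4 (0.03 log units; within the scatter) is therefore expected to be about as small, resting on compound 1 and compound 2 having shown a 1.1-fold higher number from compound 1 to compound 2 (0.05 log units; within the scatter). Compound 4 is estimated at 1400 nM, within 700 nM to 2800 nM.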

Compound 4, concentration for 50% growth inhibition: 1220 nM
Estimate against measurement, compound 4: 1.1-fold (0.06 log units) above; the measured number falls inside the stated range.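

The methoxy to hydroxy change is tolerated on both cores, and on the second it gives a 1.1-fold lower number from compound 3 to compound 4 (0.03 log units; within the scatter) in this assay without any shift that can be told from scatter. This holds for two closely related cores in one cell line only; it does not show that the change would stay as small on other cores, and a step this small says nothing about what the methyl or the hydrogen contributes. The two steps agree: the same change on two cores in this assay, a 1.1-fold higher number (0.05 log units; within the scatter) from compound 1 to compound 2 and a 1.1-fold lower number (0.03 log units; within the scatter) from compound 3 to compound 4, 1.2-fold (0.08 log units) apart, within the scatter of two such steps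

The compounds shown leave open whether a longer chain on that oxygen would move the number beyond the scatter. On these data alone, whether an amine or a carboxylic acid in place of the hydroxy would do so also remains open.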